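A few compounds are considered here, and "the series" means these few. Any claim that something is new, unique, unknown or untested is made for them only; others in the source may bear on it.

Measured in an ADME assay on WI-38 cells (Homo sapiens) for cytotoxicity, read by MTT assay, with a stated time of 72 h; on this read-out higher numbers stand for weaker inhibition and lower numbers for stronger inhibition:
compound 1 `O=C(CCc1cccc2c1B(O)OC2)NCc1ccccc1`: > 100000 nM, a limit of the assay
compound 2 `O=C(CCc1cccc2c1B(O)OC2)Nc1cccc(I)c1`: 71000 nM

Going by the values given here, compound 2 holds the only actual number in this assay, since the entry for compound 1 is a limit and not a number. Compound 3 `O=C(CCc1cccc2c1B(O)OC2)Nc1cccc(-c2cccc(Cl)c2)c1` is reached by 3-chlorophenyl in place of iodo on an aromatic carbon, with 3-chlorophenyl in place of iodo on an aromatic carbon, meta to a large group. Among the compounds with values here, the one measured step, an at least 1.4-fold lower number from compound 1 to compound 2 (0.14 log units; that floor lies within the scatter), is 3-iodophenyl in place of benzyl on an amide-type nitrogen. It lies elsewhere in the molecule and bears only loosely on this change. Within the data shown here, with that step as the sole guide, no change beyond the scatter is firmly expected, only a slight lean towards a lower number. The estimated step is a 1.6-fold lower number from compound 2 to compound 3 (0.20 log units; within the scatter). For compound 3 the estimate is 45000 nM, with an expected range of 14000 nM to 100000 nM.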

Compound 3, half-maximal inhibitory concentration: 58000 nM
Beside the measured number, compound 3's estimate is 1.3-fold (0.11 log units) below it, and the stated range covers the measured number.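

In this assay, replacing iodo with 3-chlorophenyl on an aromatic carbon, meta to a large group, gives a 1.2-fold lower number from compound 2 to compound 3 (0.09 log units; within the scatter). Going by these compounds alone, this is the first step that rests on two actual numbers, and it shows that 7 heavy atoms and one six-membered aromatic ring of carbon only can take the place of a single iodine with no change beyond the scatter in this assay. The earlier step offered only a floor, since the entry for compound 1 is a limit and not a number: the limit of > 100000 nM in this assay, at which 1 of the 3 values shown sits.

As far as these compounds go, it remains open whether a different group at this position, such as an amine or a carboxylic acid, would move the number beyond the scatter. Also open, from the compounds shown here alone, is how a longer chain between the shared core and the amide carbonyl would read.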